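A few compounds are considered here, and "the series" means these few. Any claim that something is new, unique, unknown or untested is made for them only; others in the source may bear on it.

Compound 1 `Cn1nnnc1SCC(=O)N/N=C/c1ccccc1Br` gives 20000 nM in an ADME assay on NIH3T3 cells (Mus musculus) for cytotoxicity, read by XTT assay, with a stated time of 24 h; on this read-out higher numbers stand for weaker inhibition and lower numbers for stronger inhibition.
Compound 2 `Cn1nnnc1SCC(=O)N/N=C/c1cccc(Br)c1` gives 316000 nM in this assay.
Compound 3 `Cn1nnnc1SCC(=O)N/N=C/c1ccccc1O` reaches only a limit of this assay, namely > 10000000 nM.

Compound 1 and compound 2 are built from the same atoms joined differently; the difference between the two cores is not broken down here. Against compound 1, compound 2 gives a higher number in this assay. Compound 3 is reached from compound 1 by one change, (hydroxy in place of bromo on an aromatic carbon), and the step is an at least 500-fold higher number from compound 1 to compound 3 (2.69 log units; beyond the scatter). This step cannot be sized fully, since the value of compound 3 is a limit (the limit of > 10000000 nM in this assay, at which 1 of the 3 values shown sits).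

Compound 4 `Cn1nnnc1SCC(=O)N/N=C/c1cccc(O)c1` has not yet been measured in this assay. It is reached from compound 2 by hydroxy in place of bromo on an aromatic carbon, the same kind of change as that from compound 1 to compound 3, though the hydroxy of compound 4 sits meta to a large group where that of compound 3 sits ortho to a large group. Compound 2 already stands far above compound 1 in this assay, so if this change carries a step of the size seen from compound 1 to compound 3, compound 4 is expected to reach the limit of the assay as well. Compound 4 is therefore estimated at 10000000 nM, within 2000000 nM to 60000000 nM, meaning an expected step of a 32-fold higher number from compound 2 to compound 4 (1.50 log units; beyond the scatter), resting on the step of an at least 500-fold higher number from compound 1 to compound 3 (2.69 log units; beyond the scatter) and on the value of compound 2, 316000 nM.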

Compound 4, half-maximal inhibitory concentration: 3160000 nM
Compound 4: middle estimate off by 3.2-fold (0.50 log units), on the high side; the measured number falls inside the stated range.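

Hydroxy in place of bromo on an aromatic carbon gives a 10-fold higher number from compound 2 to compound 4 (1.00 log units; beyond the scatter) in this assay, so the direction seen on the core of compound 1 recurs on the core of compound 2, while the size of the step does not carry over: the same change on two cores in this assay, an at least 500-fold higher number (2.69 log units; beyond the scatter) from compound 1 to compound 3 and a 10-fold higher number (1.00 log units; beyond the scatter) from compound 2 to compound 4, at least 50-fold (1.69 log units) apart, beyond the scatter of two such steps
The step to compound 3 cannot be sized in full, since the value of compound 3 is a limit of the assay: the limit of > 10000000 nM in this assay, at which 1 of the 4 values shown sits.
With one pair on each core, the result shows that this change cannot be carried from one core to the other at a fixed size, but it does not show what lies behind the gap, how wide the gap truly is, or whether the direction would hold on any further core.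

The compounds shown carry only bromo or hydroxy on the aromatic ring, so it stays open whether an amine, a methoxy group or a carboxylic acid in the same places would give numbers closer to those of the bromo compounds or the hydroxy compounds in this assay. Also open, on these data alone, is whether the two steps would stay this far apart with the same change made at any other place on that ring.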